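This account rests on a few compounds, and the source may have more. Where it says the series, first, only, none or still open, it means among the compounds named here.

Compounds measured in a functional assay on U-251 cells (Homo sapiens) for inhibition, read by sulforhodamine B assay, with a stated time of 48 h, tested at 10 uM; a higher number here means more inhibition at the concentration tested (going by the name of the read-out), a lower number less inhibition:
- compound 1, `Clc1ccc(-c2cn3ccnc3c(-c3ccc4ncn(C5CCCCC5)c4c3)n2)cc1`: 11.3%
- compound 2, `Brc1ccc(-c2cn3ccnc3c(-c3ccc4ncn(C5CCCCC5)c4c3)n2)cc1`: 23.7%
- compound 3, `Fc1ccccc1-c1cn2ccnc2c(-c2ccc3ncn(C4CCCCC4)c3c2)n1`: 11.4%

Compound 3 has the second highest of the three numbers. Its nearest neighbour is compound 1, which sits within the scatter of compound 3, as the step of a number 0.1 percentage points higher from compound 1 to compound 3 (within the scatter) shows. Its furthest neighbour is compound 2, and the step of a number 12.3 percentage points lower from compound 2 to compound 3 (beyond the scatter) is beyond the scatter, though only modest in size. The step between compound 1 and compound 2, a number 12.4 percentage points higher from compound 1 to compound 2 (beyond the scatter), is of the same modest size.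

Compound 4, `c1csc(-c2cn3ccnc3c(-c3ccc4ncn(C5CCCCC5)c4c3)n2)c1`, has not yet been measured. It differs from compound 3 by the change (thiophen-2-yl in place of 2-fluorophenyl on an aromatic carbon). For the measured compounds named here, two measured steps touch the same position: one replaces 4-chlorophenyl by 2-fluorophenyl with no change beyond the scatter, the other replaces 4-bromophenyl by 2-fluorophenyl with a modest drop. Going by the values given here, no measured compound carries thiophen-2-yl, so nothing shows how that group behaves here. On this evidence, compound 4 is expected to stay close to compound 3, with a step of a number 2.6 percentage points higher from compound 3 to compound 4 (within the scatter) that may well lie within the scatter.

Compound 4 is estimated at 14% in this assay, within a range from 3% to 30%.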

Compound 4, a percentage reported as inhibition, at one concentration (the size of the read-out at that concentration, not a potency): 3.92%
The estimate for compound 4 lay 10.1 percentage points above the measured number, and the stated range covers the measured number.
By their numbers in this assay, from the lowest: compounds 4, 1 and 3 (each within the scatter of the next); then compound 2.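

In this assay, for the compounds shown here, thiophen-2-yl brings the first five-membered aromatic ring to this position, and with it the first hetero atom and hydrogen-bond acceptor in this group, yet this replacement of a six-membered carbon ring gives no separable change from two of the earlier compounds: a number 7.5 percentage points lower from compound 3 to compound 4 (within the scatter) and a number 7.4 percentage points lower from compound 1 to compound 4 (within the scatter) both stay inside the usual variation. The one clear separation is a number 19.8 percentage points lower from compound 2 to compound 4 (beyond the scatter), so compound 2, with 4-bromophenyl, now stands apart from all three other compounds, while 2-fluorophenyl, 4-chlorophenyl and thiophen-2-yl cannot be told apart here. Nothing available explains why the 4-bromophenyl compound reads differently from the others or why the thiophen-2-yl ring changes so little.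

The compounds shown leave open whether an amine, a carboxylic acid or a longer chain at this position, in place of these aromatic rings, would move the number clear of the range these four compounds span. Since every number comes from a single concentration, they also leave open how the four compounds would compare in potency.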